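The source may report more compounds than this note shows. Statements on the series, on what has been measured and on what is new or still open speak of the compounds shown alone.

Measured so far:
- compound 1, `CCCCCCCCCCCCn1nnc(C(C(=O)Nc2ccc(F)cc2F)c2ccccc2)n1`: 1%
- compound 2, `CCCCCCCCCCCCn1nnc(C(C(=O)Nc2c(OC)cc(OC)cc2OC)c2ccc(OC)cc2)n1`: 61%

Of the compounds shown here, two have been tested in an assay on isolated protein for inhibition of sterol O-acyltransferase 1 (Mus musculus), tested at 0.1 uM; a higher number here means more inhibition at the concentration tested (going by the name of the read-out), a lower number less inhibition. Compound 1, `CCCCCCCCCCCCn1nnc(C(C(=O)Nc2ccc(F)cc2F)c2ccccc2)n1`, gives 1% in this assay. Compound 2, `CCCCCCCCCCCCn1nnc(C(C(=O)Nc2c(OC)cc(OC)cc2OC)c2ccc(OC)cc2)n1`, gives 61% in this assay. Compound 2 therefore holds the higher of the two numbers; the number for compound 1 lies far below it, beyond the usual scatter. Among the measured compounds shown here, no step between a closely related pair has been worked out, so the two values show only that the compounds differ widely, not which part of the structure carries the difference.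

Compound 3, `CCCCCCCCCCCCn1nnc(C(C(=O)Nc2c(OC)cc(OC)cc2OC)c2ccc(-c3ccccc3)cc2)n1`, has not yet been measured in this assay. It differs from compound 2 in one place: phenyl in place of methoxy on an aromatic carbon. For the measured compounds named here, nothing measured so far shows what a change of this kind does in this assay, so the expectation rests on compound 2 alone. The step of a number 6 percentage points lower from compound 2 to compound 3 (within the scatter) is expected to stay within the scatter, with no clear direction. Compound 3 is estimated to give 55% in this assay, within a range from 20% to 85%.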

Compound 3, a percentage reported as inhibition, at one concentration (the size of the read-out at that concentration, not a potency): 10%
The estimate for compound 3 lay 45 percentage points above the measured number; measured number outside the range, below it.
By their numbers in this assay, from the lowest: compounds 1 and 3 (each within the scatter of the next); then compound 2.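

In this assay, replacing methoxy with phenyl on this aromatic carbon, para to a large group, gives a number 51 percentage points lower from compound 2 to compound 3 (beyond the scatter). This is the only step shown that changes a single place, so it gives the first direct sign that what sits at this position can by itself decide much of the inhibition seen at the concentration tested. No supporting measurement bears on this result, and the reason for the loss remains unknown.

The exchange removes an oxygen-containing group and adds a six-membered aromatic ring in the same step, so these compounds cannot separate the effect of losing the methoxy from that of adding the phenyl. As far as these compounds go, it also remains open whether an ethoxy group, a chlorine atom or an amine at this position would keep the inhibition of compound 2, or whether the same exchange would have a similar effect with a different group on the amide nitrogen.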